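Swapping an Aromatic Ring for a Propyl Chain

This account rests on a few compounds, and the source may have more. Where it says the series, first, only, none or still open, it means among the compounds named here.

Compound 1, `Cc1nn(C)c2nc(NNC(=O)Nc3cc(Cl)nc(Cl)c3)cc(-c3ccc(Cl)s3)c12`, in an assay on isolated protein for binding affinity to sphingosine 1-phosphate receptor 2 (Homo sapiens), read by surface plasmon resonance; on this read-out higher numbers stand for weaker binding and lower numbers for tighter binding: 1980 nM
Compound 2, `Cn1ncc2c(-c3ccc(F)cc3)cc(NNC(=O)Nc3cc(F)cc(F)c3)nc21`, in this assay: 3980 nM

Of the compounds shown here, two have been measured so far, and both share a bicyclic core carrying a urea-linked hydrazine side chain. Of the two numbers shown, the one for compound 1 is the smaller, yet the gap to compound 2 lies within the usual scatter of this kind of measurement, so neither compound can be called the tighter binder on this evidence. The two measured compounds differ in several places at once. No single-change step can be read from them.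

Compound 3, `CCCc1cc(NNC(=O)Nc2cc(Cl)nc(Cl)c2)nc2c1c(C)nn2C`, has not yet been measured. It differs from compound 1 in one place: propyl in place of 5-chlorothiophen-2-yl on an aromatic carbon. An aromatic ring bearing a chlorine is thus traded for a short chain with no ring and no acceptor.

Without a measured step of this kind to lean on, the expectation rests on the change alone. An estimated step of a 2.0-fold higher number from compound 1 to compound 3 (0.31 log units; beyond the scatter) is expected, meaning somewhat weaker binding. Compound 3 is therefore estimated to give about 4000 nM, with a plausible range from 1500 nM to 12000 nM.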

Compound 3, dissociation constant: 2360 nM
For compound 3 the middle estimate is 1.7-fold (0.23 log units) above the measured one; measured number inside the range.
By their numbers in this assay, from the lowest: compounds 1, 3 and 2 (each within the scatter of the next).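

At this position, on an aromatic carbon opposite the ring nitrogen, putting propyl in place of 5-chlorothiophen-2-yl gives a 1.2-fold higher number from compound 1 to compound 3 (0.08 log units; within the scatter) in this assay, so this read-out does not separate the two compounds. On this pair, then, binding in this range does not depend on having an aromatic ring with its sulfur and chlorine at this carbon, since a short chain with no ring reads the same within the scatter. Nothing measured here explains why the two groups give matching numbers.

From the compounds shown here alone, it remains open how much variation this position accepts: a longer chain such as pentyl, an amine or a carboxylic acid on the same carbon would show whether the tolerance seen with propyl extends to other groups or belongs to this one pair. Also open, going by these compounds, is whether propyl would read the same way alongside the other parts of compound 2, which differs from compound 1 in several places at once.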